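Expected free fraction on trimming isopropyl to methyl

The source may report more compounds than this note shows. Statements on the series, on what has been measured and on what is new or still open speak of the compounds shown alone.

In an ADME assay on a cell-free system (plasma, Mus musculus) (on this read-out higher numbers stand for a larger free fraction and lower numbers for a smaller free fraction), compound 1 (`CN(C)S(=O)(=O)c1ccc(F)c(C#Cc2cc(Cl)ccc2OCC(=O)O)c1`) gives 0.029 on the shared core. Compound 3 (`CC(C)c1ccc(S(C)(=O)=O)cc1C#Cc1cc(Cl)ccc1OCC(=O)O`) stands at 0.013 as the lower of the two numbers, a gap beyond the scatter. Compound 2 (`CC(C)S(=O)(=O)c1ccc(Cl)c(C#Cc2cc(Cl)ccc2OCC(=O)O)c1`) has the entry "not determined" (no result reported) and adds no number to the comparison.

Compound 4 (`Cc1ccc(S(C)(=O)=O)cc1C#Cc1cc(Cl)ccc1OCC(=O)O`) differs from compound 3 by methyl in place of isopropyl on an aromatic carbon, para to a methylsulfonyl group. Among the measured compounds shown here, no measured pair isolates this change, so the expected size rests on thin evidence. For the measured compounds named here, the expectation in this assay is a small rise, within the scatter or close to its edge, with compound 1 at 0.029 as the only higher number available. The estimated step is a 1.8-fold higher number from compound 3 to compound 4 (0.27 log units; within the scatter) and remains an expectation. For compound 4 the estimate is 0.024 with an expected range from 0.011 to 0.05 in this read-out.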

Compound 4, unbound fraction: 0.027
Compound 4: middle estimate off by 1.1-fold (0.05 log units), on the low side, and the stated range covers the measured number.
By their numbers in this assay, from the lowest: compound 3; then compounds 4 and 1 (each within the scatter of the next).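

In this assay, methyl in place of isopropyl on this aromatic carbon, para to a methylsulfonyl group, gives a 2.1-fold higher number from compound 3 to compound 4 (0.32 log units; beyond the scatter). Among the compounds shown here, this is the first pair that isolates a single change, and it shows that the free fraction responds to the group at this position, though the step is modest. For the compounds shown here, with only one such pair, it supports no trend across substituents, and no measurement at hand accounts for the step.

Open, going by these compounds, is whether an ethyl group on the same carbon would give a number between those of compound 3 and compound 4, and whether hydrogen or methoxy there would shift the free fraction further. Also open, on these data alone, is whether the step would persist with a nitrile in place of the methylsulfonyl group.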